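A few compounds are considered here, and "the series" means these few. Any claim that something is new, unique, unknown or untested is made for them only; others in the source may bear on it.

Working notes on the series. In a functional assay on LOX IMVI cells (Homo sapiens) for cytotoxicity, read by sulforhodamine B assay, with a stated time of 48 h, tested at 0.001 uM (on this read-out higher numbers stand for a weaker effect at the one concentration tested and lower numbers for a stronger effect), compound 1 `COc1cc(C)cc(-c2c(-c3ccnc(-c4ccc(N(C)C)cc4)c3)cnn2CC#N)c1` gives 88%. Compound 2 `COc1cc(C)cc(-c2nn(CC#N)cc2-c2ccnc(-c3ccc(N(C)C)cc3)c2)c1` gives in this assay a reading of 98%, and compound 3 `COc1cc(C)cc(-c2nn(CC#N)cc2-c2ccc(-c3cccc(C(C)=O)c3)nc2)c1` gives 98%. Compound 2 stands level with compound 3 at the digits shown, together the highest of the three numbers; compound 1 lies somewhat lower, still within the scatter. At this concentration all three numbers say the same: a weak effect only.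

Compound 4 `Cc1cc(O)cc(-c2nn(CC#N)cc2-c2ccnc(-c3ccc(N(C)C)cc3)c2)c1` differs from compound 2 by hydrogen in place of methyl on an oxygen on an aromatic ring. For the measured compounds named here, no step between measured compounds shows what such a change does, so the expectation rests on the flat numbers alone. The expected step of a number 3 percentage points lower from compound 2 to compound 4 (within the scatter) is none beyond the scatter. Compound 4 is therefore estimated at 95%, with a range from 84% to 105%.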

Compound 4, a percentage reported as activity, at one concentration (the size of the read-out at that concentration, not a potency): 103%
Beside the measured number, compound 4's estimate is 8 percentage points below it; low and high end bracket the measured number.
By their numbers in this assay, from the lowest: compounds 1, 2, 3 and 4 (each within the scatter of the next, the first and the last beyond it).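

Methoxy to hydroxy on the 3-methoxy-5-methylphenyl group gives the first readable step of the series: in this assay the change stays within the scatter (a number 5 percentage points higher from compound 2 to compound 4 (within the scatter)). At the one concentration tested, hydrogen in place of methyl on this oxygen leaves the effect weak. Nothing measured here bears on the reason for this result.

As far as these compounds go, whether a longer chain such as ethyl on this oxygen, or an amine in place of the hydroxy, would shift the reading remains open. From the compounds shown here alone, with all readings showing a weak effect, what this position contributes to a stronger effect also remains open.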